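This account rests on a few compounds, and the source may have more. Where it says the series, first, only, none or still open, it means among the compounds named here.

Working notes on cytotoxicity in the series, followed in an ADME assay on BJ cells (Homo sapiens) for cytotoxicity, with a stated time of 72 h; a higher number here means that more compound is needed for the effect, a lower number that less compound is needed. Compound 1 `C=C[C@](C)(CCCC(C)C)CCc1ccc(O)cc1` gives in this assay only a limit, > 36600 nM. Compound 2 `C=C[C@@](C)(/C=C/c1ccc(Nc2ccc(OC)cc2)cc1)CCC=C(C)C` likewise gives only a limit in this assay, > 36600 nM. Compound 3 `C=C[C@@](C)(/C=C/c1ccc(Nc2ccc(OC)c(OC)c2)cc1)CCC=C(C)C` also sits at a limit in this assay, > 36600 nM. Going by the values given here, the one step between neighbours, from compound 2 to compound 3, methoxy in place of hydrogen on an aromatic carbon, comes out as a step that the two limits leave unreadable from compound 2 to compound 3; because of the limit of > 36600 nM in this assay, at which 3 of the 3 values shown sit, no step has a readable size. Compound 2 thus stands at the limit with no number of its own, and nothing beyond that shared limit can be said of how it relates to compound 1 or compound 3.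

Compound 4 `C=C[C@@](C)(/C=C/c1ccc(-c2cccc(Br)c2)cc1)CCC=C(C)C` is not yet measured. It differs from compound 2 as follows: 3-bromophenyl in place of (4-methoxyphenyl)amino on an aromatic carbon. Among the compounds with values here, the only measured step that bears on this change, from compound 2 to compound 3, is unreadable, so no measured size carries over; the expectation rests solely on every value so far sitting at the limit. For compound 4 the expected result in this assay is again a limit rather than a number, which means an expected step that the limit leaves unreadable from compound 2 to compound 4, none beyond the scatter. The estimate for compound 4 in this assay is 50000 nM, within 20000 nM to 150000 nM.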

Compound 4, half-maximal effective concentration: > 36600 nM
Compound 4 ended at the assay's limit (the forecaster's own chance of this, stated with the estimate: 85%); the middle value does not contradict the limit.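

In this assay compound 4 also gives only a limit, so no new step can be read and the change from compound 2 to compound 4 has no readable size, because all the values share one limit: the limit of > 36600 nM in this assay, at which 4 of the 4 values shown sit. The compounds shown leave open whether 3-bromophenyl in place of (4-methoxyphenyl)amino alters cytotoxicity at all, and what concentration any of compound 1, compound 2, compound 3 or compound 4 needs for the effect.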